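The source may report more compounds than this note shows. Statements on the series, on what has been measured and on what is new or still open speak of the compounds shown alone.

Measured compounds and their maximal responses in a functional assay on CHO cells for agonist activity at Alpha-2C adrenergic receptor (Homo sapiens); on this read-out lower numbers stand for smaller maximal responses and higher numbers for larger maximal responses:

- compound 1 `CS(=O)(=O)c1cccc(F)c1NCC1=NCCN1`: 93%
- compound 2 `CS(=O)(=O)c1ccc(F)cc1NCC1=NCCN1`: 91%
- compound 3 `CSc1ccc(F)cc1NCC1=NCCN1`: 97%

Going by the values given here, compound 2 gives the smallest of the three numbers, but this says little: compound 1 gives 93% and the two values lie within the scatter of each other, and the one recorded step, a number 6 percentage points higher from compound 2 to compound 3 (within the scatter), is also within the scatter. All three compounds reach close to the full response of the reference in this assay.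

Compound 4 `CS(=O)(=O)c1ccc(C(F)(F)F)cc1NCC1=NCCN1` is not yet measured. It differs from compound 2 in one place: trifluoromethyl in place of fluoro on an aromatic carbon. Among the compounds with values here, none of the measured steps exchanges fluoro for trifluoromethyl; the only measured step, from compound 2 to compound 3, replaces methylsulfanyl with methylsulfonyl and was within the scatter. The measured compounds therefore give no step that bears directly on this change, and no reason to expect a step beyond the scatter in this assay.

Compound 4 is expected to give about 90%, between 75% and 100%. This estimate means a step of a number 1 percentage points lower from compound 2 to compound 4 (within the scatter), which is expected to remain within the scatter.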

Compound 4, largest response reached (reported as maximum), in percent of the reference or control that the assay uses: 25%
The estimate for compound 4 lay 65 percentage points above the measured number; measured number outside the range, below it.
By their numbers in this assay, from the lowest: compound 4; then compounds 2, 1 and 3 (each within the scatter of the next).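

In this assay, going by these compounds alone, trifluoromethyl in place of fluoro on the aromatic carbon para to the methylsulfonyl group gives a number 66 percentage points lower from compound 2 to compound 4 (beyond the scatter), so the one exchange turns a compound with a response close to that of the reference into one with a much smaller maximal response. Within the data shown here, the only earlier step, a number 6 percentage points higher from compound 2 to compound 3 (within the scatter), changed the methylsulfonyl group while fluoro stayed on this carbon, and it left the response within the scatter; this carbon is therefore the first place where a single change is seen to alter the maximal response beyond the scatter, and fluoro and trifluoromethyl are not interchangeable there. The data shown offer no measurement that accounts for this loss of response.

As far as these compounds go, it remains open whether a chlorine atom, a methyl group, a methoxy group or a nitrile on this carbon would keep the response of compound 2 or lose it as compound 4 does. From the compounds shown here alone, it is equally open whether trifluoromethyl would have the same effect alongside the methylsulfanyl group of compound 3, or on the carbon that carries fluoro in compound 1.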